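The source may hold more compounds than are shown below. What is called first, only, known or untested is meant among the compounds shown, and "the series" means these compounds.

Three compounds have so far been measured in an assay on cells for inhibition of Amine oxidase [flavin-containing] B (Homo sapiens), read by fluorescence and Amplex Red, using microsomes, with a stated time of 15 min; on this read-out lower numbers stand for stronger inhibition and higher numbers for weaker inhibition:

compound 1 `Cc1ccc2occ(C(=O)Nc3cccc(Cl)c3)c(=O)c2c1`: 4.2 nM
compound 2 `Cc1ccc(NC(=O)c2coc3ccc(C)cc3c2=O)cc1`: 152 nM
compound 3 `COc1ccc2occ(C(=O)Nc3cccc(Cl)c3)c(=O)c2c1`: 3.94 nM

Compound 3 sits at the strong end of these numbers together with compound 1: the step of a 1.1-fold lower number from compound 1 to compound 3 (0.03 log units; within the scatter) lies within the scatter, so the two cannot be told apart. Compound 2 stands far apart from both of them, with a much weaker number.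

Compound 4 `COc1ccc2occ(C(=O)Nc3ccc(C)cc3)c(=O)c2c1` has not yet been measured. It differs from compound 3 in one place: 4-methylphenyl in place of 3-chlorophenyl on an amide-type nitrogen. The same exchange has been seen once before, going from compound 1 to compound 2, and there it brought a 36-fold higher number from compound 1 to compound 2 (1.56 log units; beyond the scatter). Among the measured compounds shown here, the only other change among the measured compounds, methoxy in place of methyl, made no difference beyond the scatter, so the methoxy core of compound 3 gives no reason to expect the exchange to behave differently here.

Compound 4 is therefore expected to show a step of about a 36-fold higher number from compound 3 to compound 4 (1.55 log units; beyond the scatter) in this assay, towards weaker inhibition. The estimate for compound 4 is 140 nM, with a likely range from 50 nM to 400 nM.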

Compound 4, half-maximal inhibitory concentration: 211 nM
Estimate against measurement, compound 4: 1.5-fold (0.18 log units) below; the range from low to high includes it.
By their numbers in this assay, from the lowest: compounds 3 and 1 (each within the scatter of the next); then compounds 2 and 4 (each within the scatter of the next).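

In this assay, placing 4-methylphenyl in place of 3-chlorophenyl on the amide-type nitrogen gives a 54-fold higher number from compound 3 to compound 4 (1.73 log units; beyond the scatter), so the large weakening is no longer a single observation and holds on both cores: the same change on two cores in this assay, a 36-fold higher number (1.56 log units; beyond the scatter) from compound 1 to compound 2 and a 54-fold higher number (1.73 log units; beyond the scatter) from compound 3 to compound 4, 1.5-fold (0.17 log units) apart, within the scatter of two such steps.
The exchange of methyl for methoxy on the aromatic carbon, already without a readable effect alongside 3-chlorophenyl, also stays within the scatter alongside 4-methylphenyl, with a 1.4-fold higher number from compound 2 to compound 4 (0.14 log units; within the scatter), so across these four compounds the two changes look independent: the same change on two cores in this assay, a 1.1-fold lower number (0.03 log units; within the scatter) from compound 1 to compound 3 and a 1.4-fold higher number (0.14 log units; within the scatter) from compound 2 to compound 4, 1.5-fold (0.17 log units) apart, within the scatter of two such steps.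

The exchange alters both the substituent and its place on the ring, so these compounds cannot say which of the two matters; 4-chlorophenyl or 3-methylphenyl on the same nitrogen would separate them. As far as these compounds go, how an amine or a carboxylic acid would behave in place of the methyl or methoxy group remains open.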